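A few compounds are considered here, and "the series" means these few. Any claim that something is new, unique, unknown or untested is made for them only; others in the source may bear on it.

Compound 1 `COc1cccc(CNCCCNc2ccnc3cc(Oc4ccccc4)ccc23)c1O` gives 9.28 in a physicochemical assay for acid dissociation.
Compound 2 `COc1ccc(-c2ccc3c(NCCCNCc4cccc(OC)c4O)ccnc3c2)cc1` gives 9.47 in this assay.
Compound 3 `COc1cccc(CNCCCNc2ccnc3cc(C4CCCCC4)ccc23)c1O` gives 9.47 in this assay.

Compound 3 sits level with compound 2 at the digits shown, and its distance from compound 1 is a number 0.19 log units higher from compound 1 to compound 3 (within the scatter), so all three values lie within the usual scatter of one another. The change that leads to compound 4 `COc1cccc(CNCCCNc2ccnc3cc(-c4ccc(C(C)(C)C)cc4)ccc23)c1O` is 4-(tert-butyl)phenyl in place of cyclohexyl on an aromatic carbon. Going by the values given here, three measured steps touch this same position: a number 0.19 log units higher from compound 1 to compound 2 (within the scatter), a number 0.19 log units higher from compound 1 to compound 3 (within the scatter), and no change at the digits printed from compound 2 to compound 3 (within the scatter). Each swapped one group for another at the same aromatic carbon, and none moved the value beyond the scatter. The swap to 4-(tert-butyl)phenyl is one more exchange at that position, so no step beyond the scatter is expected in this assay. The expected step of no change at the digits printed from compound 3 to compound 4 (within the scatter) is estimated to stay within the scatter. Compound 4 is therefore expected to give 9.47, with a range from 9.2 to 9.75.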

Compound 4, acid dissociation constant: 9.47
For compound 4 middle estimate and measured number coincide at the digits printed, and the stated range covers the measured number.
By their numbers in this assay, from the lowest: compounds 1, 2, 3 and 4 (each within the scatter of the next).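

In this assay, 4-(tert-butyl)phenyl brings 10 heavy atoms and an aromatic ring where cyclohexyl has 6 heavy atoms and a non-aromatic ring, yet the step is no change at the digits printed from compound 3 to compound 4 (within the scatter) and so stays small even with this larger exchange. The comparison with the other two groups reads the same way: the step is no change at the digits printed from compound 2 to compound 4 (within the scatter) when tert-butyl takes the place of methoxy, and a number 0.19 log units higher from compound 1 to compound 4 (within the scatter) when 4-(tert-butyl)phenyl takes the place of phenoxy. All four groups at this aromatic carbon now lie within the scatter of one another, which extends the earlier picture to a fourth, larger group.

Nothing available here explains why these values sit so close together. On these data alone, whether an amine or a carboxylic acid on this same aromatic carbon would also stay within the scatter remains open.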